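The source may report more compounds than this note shows. Statements on the series, on what has been measured and on what is new or still open speak of the compounds shown alone.

Values in a functional assay on a cell-free system (plasma, Homo sapiens), with a stated time of 3 min (on this read-out higher numbers stand for weaker inhibition and lower numbers for stronger inhibition), stand as follows
Compound 1 `CC(C)(C)[C@@H](O)C(=O)N1OCC[C@H]1C(=O)NCc1cc(Cl)ccc1-n1cnnn1` gives 1600 nM
Compound 2 `O=C(NCc1cc(Cl)ccc1-n1cnnn1)[C@@H]1CCNN1C(=O)[C@H](O)c1ccccc1` gives 930 nM
Compound 3 `O=C(NCc1cc(Cl)ccc1-n1cnnn1)[C@@H]1[C@H]2C[C@H]2CN1C(=O)[C@H](O)Cc1ccccc1` gives 1200 nM

All three lie within the scatter of one another, so compound 2 at 930 nM stands level with the other two. Compound 4 `CC(C)(C)C[C@@H](O)C(=O)N1NCC[C@H]1C(=O)NCc1cc(Cl)ccc1-n1cnnn1` is still unmeasured and departs from compound 2 with neopentyl in place of phenyl on a saturated chain carbon bound to a carbonyl carbon and an oxygen on a saturated carbon. Among the measured compounds shown here, no measured pair isolates this change. Compound 3 at 1200 nM and compound 1 at 1600 nM differ from compound 2 in core and side group yet stay within its scatter, so no shift beyond the scatter is expected in this assay here. The expected step is a 1.3-fold higher number from compound 2 to compound 4 (0.11 log units; within the scatter) in size. Compound 4 is estimated at 1200 nM (400 nM to 3500 nM).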

Compound 4, half-maximal inhibitory concentration: 1300 nM
For compound 4 the middle estimate is 1.1-fold (0.03 log units) below the measured one, and the stated range covers the measured number.
By their numbers in this assay, from the lowest: compounds 2, 3, 4 and 1 (each within the scatter of the next).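

In this assay, among the compounds shown here, the first comparison that isolates a single place gives a 1.4-fold higher number from compound 2 to compound 4 (0.15 log units; within the scatter) for neopentyl in place of phenyl on a saturated chain carbon bound to a carbonyl carbon and an oxygen on a saturated carbon. For this one pair, this read-out does not separate the aromatic ring from the open chain at this position. Nothing measured here bears on why. Still open, going by these compounds, is how an amine or a carboxylic acid would read at this place, and whether the same change would read alike on the cores of compound 1 and compound 3.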